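From naphthalen-1-yl to thiophen-2-yl on compound 1

The source may hold more compounds than are shown below. What is called first, only, known or untested is meant among the compounds shown, and "the series" means these compounds.

Measured so far in a functional assay on HCT-116 cells (Homo sapiens) for inhibition, read by sulforhodamine B assay, with a stated time of 48 h, tested at 50 uM; a higher number here means more inhibition of growth at the concentration tested, a lower number less inhibition of growth:
- compound 1 `COc1cc(/C=C/C(=O)/C=C/c2cccc3ccccc23)ccc1OCc1cn(CCOc2cc(=O)oc3ccccc23)nn1`: 83%
- compound 2 `COc1cc(/C=C/C(=O)/C=C/c2cccc3ccccc23)ccc1OCc1cn(CCCOc2cc(=O)oc3ccccc23)nn1`: 66%
- compound 3 `COc1ccc(/C=C/C(=O)/C=C/c2ccc(OCc3cn(CCCCCOc4cc(=O)oc5ccccc45)nn3)c(OC)c2)cc1OC`: 45%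

Compound 1 holds the highest of these three numbers, and its gaps to compound 2 and compound 3 both lie beyond the usual scatter. The next compound to be tested is compound 4 `COc1cc(/C=C/C(=O)/C=C/c2cccs2)ccc1OCc1cn(CCOc2cc(=O)oc3ccccc23)nn1`. It carries thiophen-2-yl in place of naphthalen-1-yl on a double-bonded chain carbon bound to a double-bonded chain carbon. Within the data shown here, no pair of measured compounds differs in just one place, so the data do not show directly what this swap does in this assay. The estimate is therefore a loose one. Compound 1 already stands at 83%, which leaves more room for a fall than for a rise, so a moderate fall is expected. The expected change is a number 15 percentage points lower from compound 1 to compound 4 (beyond the scatter). For compound 4, the estimated value is 68%, with an expected range of 45% to 88%.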

Compound 4, percent growth inhibition at one concentration: 71%
Compound 4: the middle estimate sits 3 percentage points below what was measured; low and high end bracket the measured number.
By their numbers in this assay, from the lowest: compound 3; then compounds 2 and 4 (each within the scatter of the next); then compound 1.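

In this assay, putting thiophen-2-yl in place of naphthalen-1-yl on a double-bonded chain carbon bound to a double-bonded chain carbon gives a number 12 percentage points lower from compound 1 to compound 4 (beyond the scatter), so this position does respond to the group it carries. The response is modest: a group of 5 heavy atoms with one five-membered aromatic ring replaces one of 10 heavy atoms with two six-membered aromatic rings, and compound 4 still gives 71%. Nothing measured here accounts for the size of this step.

With this single swap, the effect of losing a ring cannot be told apart from the effect of bringing in sulfur. On these data alone, how a pyridine ring, or a thiophen-2-yl carrying an amine or a carboxylic acid, would behave at this position remains open.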